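From compound 2 to compound 4 at a limit

The source may hold more compounds than are shown below. What is called first, only, known or untested is meant among the compounds shown, and "the series" means these compounds.

Compound 1 `CC(C)N(Cc1cccc(OCCCCCC(=O)O)c1)C(=O)c1ccc(-c2cccc(N(C)C)c2)cc1` gives > 26000 nM
Compound 2 `CC(C)N(Cc1cccc(OCCCCCC(=O)O)c1)C(=O)c1ccccc1` gives > 26000 nM
Compound 3 `CC(C)N(Cc1cccc(OCCCCCC(=O)O)c1)C(=O)c1ccc(-c2cccc3ccccc23)cc1` gives > 26000 nM

In an ADME assay on HepG2 cells (Homo sapiens) for cytotoxicity, read by CellTiter-Glo and resazurin assay, with a stated time of 72 h (a higher number here means that more compound is needed for the effect, a lower number that less compound is needed), compound 2 gives > 26000 nM as a limit and not as a number. The other two compounds also stand only at a limit, so the whole set rests on the limit of > 26000 nM in this assay, at which 3 of the 3 values shown sit, and no measured number exists yet.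

Compound 4 `CC(=O)Nc1cccc(-c2ccc(C(=O)N(Cc3cccc(OCCCCCC(=O)O)c3)C(C)C)cc2)c1` differs from compound 2 by 3-acetamidophenyl in place of hydrogen on an aromatic carbon, with 3-acetamidophenyl in place of hydrogen on an aromatic carbon.

The nearest measured changes are a step that the two limits leave unreadable from compound 1 to compound 2, where hydrogen replaces 3-(dimethylamino)phenyl, and a step that the two limits leave unreadable from compound 2 to compound 3, where naphthalen-1-yl replaces hydrogen. The exchange between the two larger groups, a step that the two limits leave unreadable from compound 1 to compound 3, is no more informative. None of these sizes can be read, but compound 1 and compound 3 carry an aromatic group in that place and both remain at the limit. Going by the values given here, no step of readable size is therefore expected in this assay, and no direction can be assigned.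

For compound 4 the estimated value is 30000 nM, with an expected range from 20000 nM to 60000 nM. This corresponds to an expected step that the limit leaves unreadable from compound 2 to compound 4, and a report as a limit alone is the likeliest outcome.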

Compound 4, half-maximal effective concentration: > 26000 nM
Compound 4: a limit, no number; the forecaster's own chance of this, stated with the estimate: 90%; the middle value is on the limit's open side.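

In this assay compound 4 gives > 26000 nM, a limit and not a number. Its steps from compound 1, compound 2 and compound 3 therefore cannot be read. The compounds shown leave open at what concentration any of them would reach the half-maximal effect.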